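The source may hold more compounds than are shown below. What is called first, only, known or untested is meant among the compounds shown, and "the series" means these compounds.

Three compounds that share one core and differ in the group on a carbonyl carbon have been measured in an ADME assay on HepG2 2.2.15 cells (Homo sapiens) for cytotoxicity; on this read-out lower numbers stand for higher toxicity in this test and higher numbers for lower toxicity in this test. Compound 1 `N#CCC(=O)OCCc1c(-c2ccccc2Cl)c2cc(Cl)ccc2[nH]c1=O`, with cyanomethyl on that carbon, gives 100000 nM. Compound 2 `O=C(OCCc1c(-c2ccccc2Cl)c2cc(Cl)ccc2[nH]c1=O)C1CCCC1`, with cyclopentyl there, gives 46000 nM. Compound 3 `O=C(CN1C(=O)c2ccccc2C1=O)OCCc1c(-c2ccccc2Cl)c2cc(Cl)ccc2[nH]c1=O` gives 960000 nM, the highest of the three numbers.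

Compound 4 `O=C(/C=C/c1ccccc1)OCCc1c(-c2ccccc2Cl)c2cc(Cl)ccc2[nH]c1=O` has not been measured yet. Its change from compound 3 is this: a group of 8 heavy atoms (8 carbon; one six-membered aromatic ring of carbon only) in place of a group of 12 heavy atoms (9 carbon, 1 nitrogen, 2 oxygen; one five-membered non-aromatic ring with 1 hetero atom, one six-membered aromatic ring of carbon only), on a carbonyl carbon. The entering group is 2-phenylethenyl, with 0 hydrogen-bond acceptors where the leaving group has 2.

Going by the values given here, two measured steps bear on this change: a 9.6-fold higher number from compound 1 to compound 3 (0.98 log units; beyond the scatter), which is modest, and a 21-fold higher number from compound 2 to compound 3 (1.32 log units; beyond the scatter), which is large. In both, the group that now leaves is the one found with the higher number, so losing it may well bring the number down. Among the compounds with values here, no measured compound carries 2-phenylethenyl, so this remains an inference. The closest guide is the all-carbon cyclopentyl of compound 2, at 46000 nM.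

The change expected in this assay is large and toward a lower number, estimated as a 14-fold lower number from compound 3 to compound 4 (1.14 log units; beyond the scatter). The expected value for compound 4 is 70000 nM, with an estimated range from 25000 nM to 250000 nM.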

Compound 4, half-maximal cytotoxic concentration: 230000 nM
Beside the measured number, compound 4's estimate is 3.3-fold (0.52 log units) below it, and the stated range covers the measured number.
By their numbers in this assay, from the lowest: compound 2; then compound 1; then compound 4; then compound 3.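

On this carbonyl carbon in this assay, 2-phenylethenyl gives a 4.2-fold lower number from compound 3 to compound 4 (0.62 log units; beyond the scatter), so the group of compound 3 still has the highest number of the four, but a group without its ring nitrogen and carbonyl oxygens does not have to fall to the bottom of the series. Having no hydrogen-bond acceptors does not fix the number either, since two all-carbon groups with none are clearly separated, with a 5.0-fold higher number from compound 2 to compound 4 (0.70 log units; beyond the scatter). Going by these compounds alone, the new group also stands apart from cyanomethyl, with a 2.3-fold higher number from compound 1 to compound 4 (0.36 log units; beyond the scatter), which places compound 4 second in the order and shows that swapping only this one group can shift the number in either direction, depending on the pair compared.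

No measurement here explains this order of the four groups, so the reason for it stays unknown. From the compounds shown here alone, it also remains open whether an amine, a carboxylic acid or a longer saturated chain on this carbonyl carbon would stay within the range of these four numbers or move outside it.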